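This account rests on a few compounds, and the source may have more. Where it says the series, first, only, none or still open, it means among the compounds named here.

The measured compounds:
Compound 1, `COc1ccccc1-n1cc(CN2C(=O)C[C@@H]3CC[C@@]2(C)C3(C)C)nn1`, gives 70 nM in a functional assay on LoVo cells (Homo sapiens) for inhibition, read by MTT assay, with a stated time of 24 h; a higher number here means a weaker inhibitor, a lower number a stronger inhibitor.
Compound 2, `Cc1ccc(-n2cc(CN3C(=O)C[C@@H]4CC[C@@]3(C)C4(C)C)nn2)cc1`, gives 50 nM in this assay.
Compound 3, `CC1(C)[C@H]2CC[C@]1(C)N(Cc1cn(-c3ccc(F)cc3)nn1)C(=O)C2`, gives 40 nM in this assay.

All three share the same core and differ only in the aryl group on the aromatic nitrogen of the five-membered ring with three nitrogens. Compound 3 has the lowest of the three numbers, but the gaps to the others are small: a 1.3-fold lower number from compound 2 to compound 3 (0.10 log units; within the scatter) and a 1.8-fold lower number from compound 1 to compound 3 (0.24 log units; within the scatter). Both lie within the scatter, so none of the three can be called stronger or weaker than another.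

Compound 4, `COc1cccc(-n2cc(CN3C(=O)C[C@@H]4CC[C@@]3(C)C4(C)C)nn2)c1`, has not yet been measured. It differs from compound 3 in one place: 3-methoxyphenyl in place of 4-fluorophenyl on an aromatic nitrogen. Going by the values given here, two measured steps bear on this. The step of a 1.8-fold lower number from compound 1 to compound 3 (0.24 log units; within the scatter) replaced a methoxyphenyl with the same 4-fluorophenyl that now leaves, and a 1.3-fold lower number from compound 2 to compound 3 (0.10 log units; within the scatter) swapped one small substituent on that ring for another; neither moved the number beyond the scatter. Among the compounds with values here, no measured pair compares a 2-methoxyphenyl with a 3-methoxyphenyl directly. Every aryl variation seen so far has left this assay essentially unchanged, so the expected step of a 1.4-fold higher number from compound 3 to compound 4 (0.14 log units; within the scatter) is none beyond the scatter. Compound 4 is therefore estimated at 55 nM, with a likely range from 25 nM to 130 nM.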

Compound 4, half-maximal inhibitory concentration: 80 nM
Estimate against measurement, compound 4: 1.5-fold (0.16 log units) below, within the range that was stated.
By their numbers in this assay, from the lowest: compounds 3, 2, 1 and 4 (each within the scatter of the next).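

In this assay, the series now holds its first direct comparison of two placements of the methoxy group on the same phenyl ring: 3-methoxyphenyl in place of 2-methoxyphenyl gives a 1.1-fold higher number from compound 1 to compound 4 (0.06 log units; within the scatter), so the two groups cannot be told apart here. Against the other two aryl groups, 3-methoxyphenyl in place of 4-fluorophenyl gives a 2.0-fold higher number from compound 3 to compound 4 (0.30 log units; within the scatter), the widest gap among the four compounds, and 3-methoxyphenyl in place of 4-methylphenyl gives a 1.6-fold higher number from compound 2 to compound 4 (0.20 log units; within the scatter); even that widest gap stays within the scatter, so this position on the aromatic nitrogen has accepted all four substituted phenyl groups without a readable change, and they cannot be ranked. No measurement offered alongside these numbers speaks to why the values fall where they do.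

Still open, going by these compounds, is whether a phenyl ring carrying an amine or a carboxylic acid, or a longer chain such as benzyl in place of the phenyl ring, would move the number beyond the scatter. On these data alone, all four compounds also share the same core, so how far the number depends on that core remains open too.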